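The compounds below may be only part of what the source reports. "The series", "measured", "known", "first", "only" and "open" are said of these compounds alone.

Compound 1 `N#Cc1c(Cl)n(C2O[C@H](CO)[C@@H](O)[C@H]2O)c2cc(Cl)c(Cl)cc12` gives 35000 nM in a functional assay on KB cells (Homo sapiens) for cytotoxicity, read by spectrophotometry and crystal violet staining (on this read-out higher numbers stand for weaker inhibition and lower numbers for stronger inhibition), the lower of the two numbers recorded there; compound 2 `CC(=O)c1c(Cl)n([C@H]2C[C@H](O)[C@@H](CO)O2)c2cc(Cl)c(Cl)cc12` gives 400000 nM in this assay, a higher number beyond the usual scatter. Compound 3 `C[C@H]1OC(n2c(Cl)c(C#N)c3cc(Cl)c(Cl)cc32)[C@H](O)[C@@H]1O` has not been measured in this assay. It differs from compound 1 in one place: hydrogen in place of hydroxy on a saturated chain carbon bound to a saturated ring carbon. Among the measured compounds shown here, no measured pair shows this change, so the step is expected to be modest and toward a higher number, if beyond the scatter at all, given as a 2.3-fold higher number from compound 1 to compound 3 (0.36 log units; beyond the scatter). Compound 3 is expected to give about 80000 nM in this assay, within a range of 20000 nM to 400000 nM.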

Compound 3, half-maximal inhibitory concentration: 40000 nM
Compound 3: the middle estimate sits 2.0-fold (0.30 log units) above what was measured, and the stated range covers the measured number.
By their numbers in this assay, from the lowest: compounds 1 and 3 (each within the scatter of the next); then compound 2.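

In this assay, replacing hydroxymethyl with methyl on the core of compound 1 gives a 1.1-fold higher number from compound 1 to compound 3 (0.06 log units; within the scatter). Among the compounds shown here, this is the first reading of this position: the hydroxy on this saturated chain carbon can give way to hydrogen with no difference beyond the scatter, so this read-out does not depend on that hydroxy here. Nothing at hand accounts for this result. On these data alone, whether an amine, a carboxylic acid or a longer chain at this place would also stay within the scatter remains open. So does whether the same change would read alike on the core of compound 2.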